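Halogen Swap on a Carbocyclic Nucleoside Core: Cytotoxicity Outlook

The source may report more compounds than this note shows. Statements on the series, on what has been measured and on what is new or still open speak of the compounds shown alone.

compound 1, `Nc1ncc(Br)c2c1ncn2[C@@H]1C[C@H](O)[C@@H](O)[C@H]1O`: > 273000 nM
compound 2, `Nc1ncc(I)c2c1ncn2[C@@H]1C[C@H](O)[C@@H](O)[C@H]1O`: 67000 nM

Of the compounds shown here, two sharing the same core have been tested in an ADME assay on CV-1 cells (Chlorocebus aethiops) for cytotoxicity; on this read-out higher numbers stand for lower toxicity in this test and lower numbers for higher toxicity in this test. In this assay compound 1 reaches only a limit of the assay, > 273000 nM. In this assay, within the data shown here, compound 2 gives 67000 nM, the single actual number among the values shown. The difference between them is an at least 4.0-fold lower number from compound 1 to compound 2 (0.61 log units; beyond the scatter), the change being iodo in place of bromo on an aromatic carbon.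

Compound 3 `Nc1ncc(Cl)c2c1ncn2[C@@H]1C[C@H](O)[C@@H](O)[C@H]1O` has not yet been measured. It differs from compound 2 by chloro in place of iodo on an aromatic carbon. Among the measured compounds shown here, the only measured step that bears on this change is an at least 4.0-fold lower number from compound 1 to compound 2 (0.61 log units; beyond the scatter), which ran in the opposite direction, from a lighter halogen to a heavier one. Reversing toward a lighter halogen is therefore expected to move the number upward, possibly back to the limit of > 273000 nM in this assay, at which 1 of the 2 values shown sits. Compound 3 is expected to give 200000 nM, with a range from 67000 nM to 600000 nM. That estimate means an expected step of a 3.0-fold higher number from compound 2 to compound 3 (0.47 log units; beyond the scatter).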

Compound 3, half-maximal cytotoxic concentration: 311000 nM
The estimate for compound 3 lay 1.6-fold (0.19 log units) below the measured number, within the range that was stated.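

On the aromatic carbon para to an amino group, chloro in place of iodo gives in this assay a step that can be read at both ends, a 4.6-fold higher number from compound 2 to compound 3 (0.67 log units; beyond the scatter), whereas the earlier step from bromo to iodo started from a limit. Compound 3 therefore joins compound 2 with an actual number, and at this position on the shared core the iodo compound stands clearly lower than the chloro compound. Compound 1 remains a limit of the assay, and the step from compound 1 to compound 3 cannot be read: the limit of > 273000 nM in this assay, at which 1 of the 3 values shown sits.

The compounds shown therefore leave open whether bromo lies closer to chloro or to iodo, so no full order of the three halogens can be stated in this assay. They also leave open how a fluoro, a methyl, a nitrile or an amine on this same aromatic carbon would compare with the halogens, and whether the gap between chloro and iodo would persist if the hydroxyl groups on the shared core were replaced by methoxy groups.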